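Notes on compound 3: methoxy in place of fluoro

The compounds below may be only part of what the source reports. "The series", "measured", "known", "first", "only" and "open" are said of these compounds alone.

Measured in a functional assay on THP-1 cells (Homo sapiens) for inhibition, read by ELISA, with stated times of 2 h and 48 h; a lower number here means a stronger inhibitor, a higher number a weaker inhibitor:
compound 1, `CCOC1=C(/C(C)=N/OCC(=O)Nc2cccc(OC)c2)N(C)S(=O)(=O)c2ccccc21`: > 20000 nM, a limit of the assay, not a number.
compound 2, `C/C(=N\OCC(=O)Nc1cccc(F)c1)C1=C(O)c2ccccc2S(=O)(=O)N1C`: > 20000 nM, a limit of the assay, not a number.

Compound 2 stands at the limit of this assay and gives no number. Compound 1 sits at that same limit, so both values shown are limits (the limit of > 20000 nM in this assay, at which 2 of the 2 values shown sit).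

Compound 3, `COc1cccc(NC(=O)CO/N=C(\C)C2=C(O)c3ccccc3S(=O)(=O)N2C)c1`, differs from compound 2 in one place: methoxy in place of fluoro on an aromatic carbon. Going by the values given here, no measured step is available for guidance, and with both values at the limit of > 20000 nM in this assay, at which 2 of the 2 values shown sit, the expected step in this assay, a step that the limit leaves unreadable from compound 2 to compound 3, is none beyond the scatter. Compound 3 is expected to come out near 30000 nM, between 10000 nM and 100000 nM, most probably again only as a limit.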

Compound 3, half-maximal inhibitory concentration: > 20000 nM
Compound 3 gave a limit, no number; the forecaster's own chance of this, stated with the estimate: 80%; the middle value is on the limit's open side.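

No step can be read between compound 1, compound 2 and compound 3, as all three give only a limit and no number: the limit of > 20000 nM in this assay, at which 3 of the 3 values shown sit.

The compounds shown leave open whether methoxy in place of fluoro, or hydrogen in place of ethyl, changes inhibition in this assay at all.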